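The compounds below may be only part of what the source reports. "The series", "measured", "known", "first", "only" and "open" are said of these compounds alone.

Working notes on the series. Compound 1 `COC1CCN(CC(=O)N2CCN(c3sc(C(F)(F)F)nc3-c3nc4ccccc4[nH]3)C[C@H]2C)C1` gives 3380 nM in a functional assay on Venous blood for antagonist activity at C-X-C chemokine receptor type 3 (Homo sapiens), read by flow cytometry, with a stated time of 30 min, in the presence of a further agent that is not named here (a lower number here means a stronger inhibitor, a higher number a weaker inhibitor), the highest number of the three measured compounds. Compound 2 `Cc1nc(C)n(CC(=O)N2CCN(c3sc(C(F)(F)F)nc3-c3nc4ccc(C5CCOCC5)cc4[nH]3)C[C@H]2C)n1` gives 123 nM in this assay, and compound 3 `C[C@@H]1CN(c2sc(C(F)(F)F)nc2-c2nc3cc(Cl)ccc3[nH]2)CCN1C(=O)Cn1cnc2cccnc21` gives 38.5 nM in this assay; both gaps from compound 1 lie beyond the scatter, so compound 1 is the weakest inhibitor of the three. Compound 4 `C[C@@H]1CN(c2sc(C(F)(F)F)nc2-c2nc3ccccc3[nH]2)CCN1C(=O)CN1CCC(F)(F)CC1` is not yet measured. Its change from compound 1 is 4,4-difluoropiperidin-1-yl in place of 3-methoxypyrrolidin-1-yl on a saturated chain carbon bound to a carbonyl carbon. Going by the values given here, no measured pair differs only in this way, and compounds 2 and 3 differ from compound 1 at several places at once, so no direction can be read off. The expected step is small, estimated at about a 1.5-fold lower number from compound 1 to compound 4 (0.19 log units; within the scatter). Compound 4 is estimated at 2200 nM in this assay, within 600 nM to 7000 nM.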

Compound 4, half-maximal inhibitory concentration: 2430 nM
Estimate against measurement, compound 4: 1.1-fold (0.04 log units) below; the range from low to high includes it.
By their numbers in this assay, from the lowest: compound 3; then compound 2; then compounds 4 and 1 (each within the scatter of the next).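

In this assay, going by these compounds alone, this is the first pair that differs in one place, and it gives a 1.4-fold lower number from compound 1 to compound 4 (0.14 log units; within the scatter). On a saturated chain carbon bound to a carbonyl carbon, 4,4-difluoropiperidin-1-yl and 3-methoxypyrrolidin-1-yl therefore cannot be told apart, although one is a six-membered ring and the other a five-membered ring. Nothing on hand offers an explanation for this result. Going by these compounds, whether a carboxylic acid or a primary amine at this place would separate from these two rings remains open. The compounds shown also do not separate this position from the other places where compound 2 and compound 3 differ from compound 1.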